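Ether to alcohol on the shared core, a cut to hydroxy

This account rests on a few compounds, and the source may have more. Where it says the series, first, only, none or still open, it means among the compounds named here.

Measured so far:
compound 1 `CCO[C@H]1CC=C2CCN(C)[C@H]2C1`, > 300000 nM
compound 2 `CN1CCC2=CC[C@H](OCc3ccccc3)C[C@@H]21`, 300000 nM

Compound 1 was read in an assay on HEK293 cells for displacement of a labelled ligand from Neuronal acetylcholine receptor; alpha3/beta4 (Rattus norvegicus), with a stated time of 4 h (a lower number here means a stronger inhibitor, a higher number a weaker inhibitor), and gives only a limit there, > 300000 nM; the value is a limit of the assay, not a number. Compound 2 carries phenyl in place of methyl on the saturated chain carbon bound to the oxygen on the saturated carbon and in this assay gives 300000 nM. The step of a number no higher from compound 1 to compound 2 (the limit leaves the size open) is therefore not readable in size, since one end of it sits at the limit (the limit of > 300000 nM in this assay, at which 1 of the 2 values shown sits).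

Compound 3 `CN1CCC2=CC[C@H](O)C[C@@H]21` is the alcohol of the series: hydrogen in place of ethyl on an oxygen on a saturated carbon. Going by the values given here, the only measured step, from the ether of compound 1 to the benzyl ether of compound 2, gives no readable size, so nothing here fixes the direction or size of a change at the oxygen. Compound 3 is expected at 300000 nM with a range from 100000 nM to 1000000 nM. This estimate means a step of a number no higher from compound 1 to compound 3 (the limit leaves the size open), which is expected to stay within the scatter, and a limit rather than a number is the likelier read-out.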

Compound 3, inhibition constant: > 300000 nM
Compound 3 was reported as a limit; the forecaster's own chance of this, stated with the estimate: 70%; the middle value sits exactly at the limit.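

In this assay compound 3 gives > 300000 nM as a limit of the assay, not a number. No step between compound 1 and compound 3 can be read, because both stand at a limit: the limit of > 300000 nM in this assay, at which 2 of the 3 values shown sit.

The compounds shown leave open whether any change at the oxygen on the shared core shifts binding at all.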